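Moving the Bromine Around the Ring of Compound 3

The source may hold more compounds than are shown below. What is called first, only, known or untested is meant among the compounds shown, and "the series" means these compounds.

Compound 3 `COc1cc(CNC(=S)NC(CCc2ccc(C(C)(C)C)cc2)COC(=O)C(C)(C)C)cc(Br)c1O` gives 143 nM in an assay on CHO cells for displacement of a labelled ligand from transient receptor potential cation channel subfamily V member 1 (Rattus norvegicus) (a higher number here means a weaker inhibitor, a lower number a stronger inhibitor), the highest of the three numbers measured here. Its nearest neighbour is compound 2 `COc1cc(CNC(=S)NC(CCc2ccc(C(C)(C)C)cc2)COC(=O)C(C)(C)C)cc(Cl)c1O`, which gives 122 nM; the step of a 1.2-fold higher number from compound 2 to compound 3 (0.07 log units; within the scatter) is small. Furthest away is compound 1 `COc1cc(CNC(=S)NCC(COC(=O)C(C)(C)C)Cc2ccc(C(C)(C)C)cc2)c(I)cc1O`, which gives 13.3 nM, a clearly lower number and thus a stronger inhibitor.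

Compound 4 `COc1cc(CNC(=S)NC(CCc2ccc(C(C)(C)C)cc2)COC(=O)C(C)(C)C)c(Br)cc1O` keeps every atom of compound 3 but places the bromine differently: 2-bromo-4-hydroxy-5-methoxyphenyl in place of 3-bromo-4-hydroxy-5-methoxyphenyl on a saturated chain carbon bound to an amide-type nitrogen. Going by the values given here, no measured step covers such a move of a halogen around the ring. Among the compounds with values here, the only measured step, from compound 2 to compound 3, swaps one halogen for another and stays within the scatter, so it offers no guide. Compound 1 carries its halogen in a position described by the same ring pattern that enters in compound 4, but compound 1 also differs in how its chain is built, so its strong value cannot be attributed to the halogen position alone.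

Taking that hint cautiously, compound 4 is expected to show a step of a 2.4-fold lower number from compound 3 to compound 4 (0.38 log units; beyond the scatter), a modest move toward a lower number, with wide uncertainty. The estimate for compound 4 is 60 nM, likely falling between 20 nM and 200 nM.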

Compound 4, inhibition constant: 75 nM
Compound 4: the middle estimate sits 1.3-fold (0.10 log units) below what was measured; the range from low to high includes it.
By their numbers in this assay, from the lowest: compound 1; then compounds 4, 2 and 3 (each within the scatter of the next).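

In this assay, with the chain held fixed, 2-bromo-4-hydroxy-5-methoxyphenyl in place of 3-bromo-4-hydroxy-5-methoxyphenyl gives a 1.9-fold lower number from compound 3 to compound 4 (0.28 log units; within the scatter), so this test of the halogen's placement alone separates the two compounds by no more than repeat measurements would. Changing both the halogen and its placement gives a 1.6-fold lower number from compound 2 to compound 4 (0.21 log units; within the scatter), so compound 2, compound 3 and compound 4 cannot be told apart in this assay, and neither change has a clear effect on this chain. No measurement available here offers an explanation for these results.

From the compounds shown here alone, what stays open is how far this position tolerates something other than a halogen. A nitrile or a methyl group in place of the bromine on this same chain might or might not give a number beyond the scatter of these three compounds.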